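A few compounds are considered here, and "the series" means these few. Any claim that something is new, unique, unknown or untested is made for them only; others in the source may bear on it.

Measured so far:
compound 1 `COc1cc(-c2nn(-c3cccc(NC(=O)c4cccc(C(F)(F)F)c4)c3)cc2-c2ccncc2)ccc1Cl` — in a functional assay on ACHN cells (Homo sapiens) for inhibition, read by sulforhodamine B assay, with a stated time of 48 h (a lower number here means a stronger inhibitor of growth, a higher number a weaker inhibitor of growth), compound 1 gives 1890 nM
compound 2 `COc1cc(-c2nn(-c3cccc(NC(=O)Nc4ccc(Cl)c(Cl)c4)c3)cc2-c2ccncc2)ccc1Cl` — compound 2 gives 1000 nM
compound 3 `COc1cc(-c2nn(-c3cccc(NC(=O)Nc4cccc(C(F)(F)F)c4)c3)cc2-c2ccncc2)ccc1Cl` — compound 3 gives 656 nM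

Compound 3 has the lowest number of the three. Compound 2 sits within the scatter of it, whereas compound 1 lies beyond it, by the step of a 2.9-fold lower number from compound 1 to compound 3 (0.46 log units; beyond the scatter). Compound 4 `COc1cc(-c2nn(-c3cccc(NC(=O)c4ccc(Cl)c(C(F)(F)F)c4)c3)cc2-c2ccncc2)ccc1Cl` is not yet measured. It differs from compound 3 by 4-chloro-3-(trifluoromethyl)phenyl in place of (3-(trifluoromethyl)phenyl)amino on a carbonyl carbon; the carbonyl carbon thus carries an aryl ring directly, as in compound 1, here one bearing both a chlorine and a trifluoromethyl. The step that bears on this most directly is a 2.9-fold lower number from compound 1 to compound 3 (0.46 log units; beyond the scatter), the same exchange run the other way; its reverse points to a higher number for compound 4. The step of a 1.9-fold lower number from compound 1 to compound 2 (0.28 log units; within the scatter) shows that swapping the substituent pattern on the aryl ring moved the number only within the scatter, so the number for compound 4 is expected to be set mainly by the return to the amide-type carbonyl. Compound 4 is therefore expected to show a moderately higher number than compound 3, a 2.0-fold higher number from compound 3 to compound 4 (0.30 log units; within the scatter). The estimate for compound 4 is 1300 nM, with a range from 500 nM to 3500 nM.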

Compound 4, concentration for 50% growth inhibition: 2730 nM
For compound 4 the middle estimate is 2.1-fold (0.32 log units) below the measured one; the measured number falls inside the stated range.
By their numbers in this assay, from the lowest: compounds 3, 2, 1 and 4 (each within the scatter of the next, the first and the last beyond it).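

In this assay the chloro added to the aryl ring on the carbonyl carbon changes little: a 1.4-fold higher number from compound 1 to compound 4 (0.16 log units; within the scatter). With this second directly attached aryl ring the higher number recurs against both arylamino compounds, a 4.2-fold higher number from compound 3 to compound 4 (0.62 log units; beyond the scatter) and a 2.7-fold higher number from compound 2 to compound 4 (0.44 log units; beyond the scatter), although compound 1 and compound 2 stay closer, a 1.9-fold lower number from compound 1 to compound 2 (0.28 log units; within the scatter). Nothing at hand accounts for these steps.

The compounds shown leave open what the chloro does when the ring is held on the amino link, as in a (4-chloro-3-(trifluoromethyl)phenyl)amino group on the carbonyl carbon. Also open, going by these compounds, is how a methylene chain between the carbonyl carbon and the aryl ring, or a dimethylamino group on that ring, would read.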